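This account rests on a few compounds, and the source may have more. Where it says the series, first, only, none or still open, it means among the compounds named here.

Three compounds share a purine-based core carrying a cyclopropyl group and a glycine-type linker to a benzyl ester of an amino acid. Compound 1 `O=C(CN(c1ncnc2c1ncn2C1CCCCO1)C1CC1)N[C@@H](CO)C(=O)OCc1ccccc1` is built on a serine; in a functional assay on the whole organism (Tail, strain ICR) with Mus musculus as the target, in the tail flick test, with a stated time of 150 min, at a dose of 25 umol/kg by the oral route (on this read-out lower numbers stand for a weaker effect and higher numbers for a stronger effect at the one dose given), compound 1 gives 18.3%. Compound 3 `CC(C)[C@H](NC(=O)CN(c1ncnc2c1ncn2C1CCCCO1)C1CC1)C(=O)OCc1ccccc1` carries a valine in the same place, and in this assay compound 3 gives 21.1%. Compound 2 `NCCCC[C@H](NC(=O)CN(c1nc(Cl)nc2[nH]cnc12)C1CC1)C(=O)OCc1ccccc1` has a chloro substituent on its core and a lysine-type chain; in this assay compound 2 gives 9.88%, the smallest of the three numbers, with its gap to compound 1 inside the scatter and only its gap to compound 3 beyond it.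

Compound 4 `NC(=O)CC[C@H](NC(=O)CN(c1nc(Cl)nc2[nH]cnc12)C1CC1)C(=O)OCc1ccccc1` differs from compound 2 in one place: carbamoyl in place of 2-aminoethyl on a saturated chain carbon, three bonds along the chain from an amide-type nitrogen and a carbonyl carbon. For the measured compounds named here, the only measured step that touches the same region is the exchange of the amino-acid side chain from compound 1 to compound 3, a number 2.8 percentage points higher from compound 1 to compound 3 (within the scatter). Going by the values given here, that step shows a side-chain change leaving the read-out essentially unmoved, and no measured pair shows the amine-to-carbamoyl swap itself. On that basis the expected step is a number 2.1 percentage points higher from compound 2 to compound 4 (within the scatter), none beyond the scatter. Compound 4 is therefore estimated at 12%, within a range from 2% to 25%.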

Compound 4, a percentage reported as activity, at one dose (the size of the read-out at that dose, not a potency): 31.1%
Compound 4: middle estimate off by 19.1 percentage points, on the low side, outside the stated range (above it).
By their numbers in this assay, from the lowest: compounds 2, 1, 3 and 4 (each within the scatter of the next, the first and the last beyond it).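

Carbamoyl in place of 2-aminoethyl, on a saturated chain carbon, three bonds along the chain from an amide-type nitrogen and a carbonyl carbon, gives a number 21.2 percentage points higher from compound 2 to compound 4 (beyond the scatter) in this assay. For the compounds shown here, this is the first single change to move the read-out beyond the scatter, whereas the only earlier one in this region, a number 2.8 percentage points higher from compound 1 to compound 3 (within the scatter) on a different core, did not, so the amino-acid side chain can matter here. The two groups match in heavy-atom count and in hydrogen-bond donors and acceptors, and the carbamoyl differs in holding an oxygen and a double bond, but nothing measured here gives a reason for the rise.

As far as these compounds go, whether a carboxylic acid in the same place or a longer chain ending in the carbamoyl would hold this level remains open. Also open, from the compounds shown here alone, is whether the same exchange would act in the same way on the core of compound 1, and whether the rise would hold at other doses, as this single pair at one dose cannot say.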